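Benzyloxy for Piperidinyl Beside the Ring Nitrogen

This account rests on a few compounds, and the source may have more. Where it says the series, first, only, none or still open, it means among the compounds named here.

Compound 1: `CC1CCN(c2nc(C(F)F)ccc2CNC(=O)C(C)c2ccc(NS(C)(=O)=O)c(F)c2)CC1`, 1 nM
Compound 2: `CC1CCN(c2nc(-c3ccc(F)cc3)ccc2CNC(=O)C(C)c2ccc(NS(C)(=O)=O)c(F)c2)CC1`, 59 nM
Compound 3: `CC(C(=O)NCc1ccc(C(F)(F)Cl)nc1N1CCCCC1)c1ccc(NS(C)(=O)=O)c(F)c1`, 1.3 nM

In an assay on CHO cells for antagonist activity at transient receptor potential cation channel subfamily V member 1 (Homo sapiens), read by FLIPR (a higher number here means a weaker inhibitor, a lower number a stronger inhibitor), compound 3 gives 1.3 nM, the second highest of the three numbers, nearest to compound 1 and within the scatter of it, while compound 2 stands far higher than both. Compound 4 is `CC(C(=O)NCc1ccc(C(F)(F)Cl)nc1OCc1ccccc1)c1ccc(NS(C)(=O)=O)c(F)c1` and has not been measured. It differs from compound 3 in one place: benzyloxy in place of piperidin-1-yl on an aromatic carbon.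

Within the data shown here, only one single-point step has been measured in this set, and it sits elsewhere on the core: a 59-fold higher number from compound 1 to compound 2 (1.77 log units; beyond the scatter). Among the measured compounds shown here, that step shows the series can lose a great deal of potency when an aromatic ring is introduced on the core, but it does not concern the position that changes here, and compounds 1 and 3 differ in two places at once, so they give no step for the piperidinyl position. The expectation for compound 4 therefore rests on thin ground; a loss is judged more likely than a gain, and the step is estimated as a 7.7-fold higher number from compound 3 to compound 4 (0.89 log units; beyond the scatter). Compound 4 is accordingly expected to give about 10 nM in this assay, with a range from 2 nM to 60 nM.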

Compound 4, inhibition constant: 0.9 nM
Compound 4: middle estimate off by 11-fold (1.05 log units), on the high side; the measured number lies below the stated range.
By their numbers in this assay, from the lowest: compounds 4, 1 and 3 (each within the scatter of the next); then compound 2.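

In this assay, the first step read at this position is a 1.4-fold lower number from compound 3 to compound 4 (0.16 log units; within the scatter), so piperidin-1-yl and benzyloxy cannot be told apart here, even though a non-aromatic ring with one hetero atom leaves and an aromatic ring of carbon only enters. The earlier step, a 59-fold higher number from compound 1 to compound 2 (1.77 log units; beyond the scatter), brought in a 4-fluorophenyl group elsewhere on the shared core and lay beyond the scatter, whereas this place, on an aromatic carbon next to the ring nitrogen, takes a group with an aromatic ring and more heavy atoms with no change beyond the scatter. Nothing available accounts for this difference between the two places.

Going by these compounds, whether this place would also accept a small group such as methoxy, a primary amine, or a longer chain such as phenethoxy remains open. Also open, on these data alone, is whether benzyloxy would give a similar result with difluoromethyl in place of the chloro(difluoro)methyl group, since this position has so far been read only against that one group and in this single assay.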